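The source may report more compounds than this note shows. Statements on the series, on what has been measured and on what is new or still open speak of the compounds shown alone.

On these data alone, the account turns on a compound whose number is still open. Compound 1, `CS(=O)(=O)Nc1ccc(Cl)c2c1CCCC2c1c[nH]cn1`, has been examined in an assay on isolated protein (Cricetulus griseus) for binding affinity to Alpha-1B adrenergic receptor (Mesocricetus auratus), read by radioligand binding (a lower number here means a stronger inhibitor, a higher number a weaker inhibitor), and for compound 1 the assay returns only a limit, < 10000 nM. The same limit appears for compound 3, `CS(=O)(=O)Nc1cccc2c1OCCC2c1c[nH]cn1`, which in this assay gives < 10000 nM. Among the measured compounds shown here, compound 2, `CCS(=O)(=O)Nc1cccc2c1CCCC2c1c[nH]cn1`, is the one member of the set with a plain figure: in this assay compound 2 gives 1320 nM. So compound 1 stands among the values that the assay did not resolve, a position shared with one other compound, as the limit of < 10000 nM in this assay, at which 2 of the 3 values shown sit, records.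

The change to compound 4, `CS(=O)(=O)Nc1ccc(O)c2c1CCCC2c1c[nH]cn1`, is a single one, (hydroxy in place of chloro on an aromatic carbon). For the measured compounds named here, no step between measured compounds is available to calibrate it. The expectation is nonetheless that compound 4 will move into the measurable range of this assay, with a step that the limit leaves unreadable from compound 1 to compound 4 that is estimated to be modest and toward a resolved figure rather than another limit. Compound 4 is therefore expected to give about 2500 nM, in a range from 600 nM to 9000 nM.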

Compound 4, inhibition constant: < 10000 nM
Compound 4 was reported as a limit; the forecaster's own chance of this, stated with the estimate: 25%; the middle value lies beyond the limit too.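

Among the compounds shown here, compound 1 and compound 4 are both reported only as limits, so no step between them can be read: the limit of < 10000 nM in this assay, at which 3 of the 4 values shown sit. The compounds shown leave open whether hydroxy in place of chloro on an aromatic carbon changes the result in this assay at all, and in which direction.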